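The compounds below may be only part of what the source reports. "The series", "measured", "known", "first", "only" and "open" are said of these compounds alone.

Of the compounds shown here, two of a shared core have been measured so far. Compound 1 `COc1cc2cc(Oc3ccc(NC(=O)Nc4ccccc4)cc3)c(C)nc2cc1OC` and compound 2 `COc1cc2cc(Oc3ccc(NC(=O)Nc4cccc(C(F)(F)F)c4)cc3)c(C)nc2cc1OC` differ only at the outer ring of the urea, where compound 2 carries a trifluoromethyl group. In a functional assay on SK-MEL-5 cells (Homo sapiens) for inhibition, read by sulforhodamine B assay, with a stated time of 48 h, tested at 10 uM (on this read-out lower numbers stand for a stronger effect and higher numbers for a weaker effect at the one concentration tested), compound 1 gives 60.8%, while compound 2 gives -86.1%. Among the measured compounds shown here, the step between them, a number 146.9 percentage points lower from compound 1 to compound 2 (beyond the scatter), is far beyond the scatter, so compound 2 stands as the lowest of the two numbers, with compound 1 as its only neighbour.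

Compound 3 `COc1cc2cc(Oc3ccc(NC(=O)Nc4ccc(Cl)c(C(F)(F)F)c4)cc3)c(C)nc2cc1OC` takes one further step from compound 2: chloro in place of hydrogen on an aromatic carbon. For the measured compounds named here, no measured pair shows the effect of adding a chloro group, so the only step that bears on this change is the one from compound 1 to compound 2, which was large and downward. That step shows that what sits on this ring can move the read-out strongly, but it says nothing about a chloro group itself. The expected step is therefore small, a number 5.9 percentage points lower from compound 2 to compound 3 (within the scatter), pointing slightly lower. Compound 3 is estimated to give -92%, with a likely range from -115% to -55%.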

Compound 3, a percentage reported as activity, at one concentration (the size of the read-out at that concentration, not a potency): -73.4%
Estimate against measurement, compound 3: 18.6 percentage points below; low and high end bracket the measured number.
By their numbers in this assay, from the lowest: compound 2; then compound 3; then compound 1.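

In this assay the chloro group gives the first direct view of this change: placed ortho to a trifluoromethyl group and para to a large group, it produces a number 12.7 percentage points higher from compound 2 to compound 3 (beyond the scatter) and so moves the read-out modestly toward a weaker effect rather than extending the drop. The ring as a whole still stands far from the unsubstituted phenyl, with a number 134.2 percentage points lower from compound 1 to compound 3 (beyond the scatter) compared with a number 146.9 percentage points lower from compound 1 to compound 2 (beyond the scatter) for trifluoromethyl on its own, so this position tolerates the added chloro group while keeping most of the large shift. No measurement at hand explains why the chloro group moves the number upward.

The compounds shown leave open what a chloro group does on the plain phenyl ring of compound 1 without the trifluoromethyl group, so it cannot be said whether the modest upward step belongs to chloro in general or only to this pairing. They also leave open how other groups would behave at this same place on the ring, such as a fluoro, a methoxy, a nitrile or an amine.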